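The source may hold more compounds than are shown below. What is called first, only, known or untested is meant among the compounds shown, and "the series" means these compounds.

Of the compounds shown here, two have been tested so far in an ADME assay on HEK293 cells (Homo sapiens) for cytotoxicity, with a stated time of 72 h; a higher number here means that more compound is needed for the effect, a lower number that less compound is needed. Compound 1 (`C=C[C@@](C)(/C=C/c1ccc(OS(=O)(=O)C(F)(F)F)cc1)CCC=C(C)C`) gives > 36600 nM, which is a limit of the assay and not a number. Compound 2 (`C=C[C@@](C)(/C=C/c1ccc(Nc2ccc(OC)c(F)c2)cc1)CCC=C(C)C`) gives > 36600 nM, which is also a limit and not a number. Compound 2 therefore has no exact value and stands at the limit of > 36600 nM in this assay, at which 2 of the 2 values shown sit. Compound 3 (`C=C[C@@](C)(/C=C/c1ccc(Nc2ccc(F)c(F)c2)cc1)CCC=C(C)C`) keeps the core of compound 2 but changes from 3-fluoro-4-methoxyphenyl to 3,4-difluorophenyl, with fluoro in place of methoxy on an aromatic carbon. Going by the values given here, no measured pair shows what this swap does in this assay, so no change beyond the usual scatter is expected, and the estimated step is a number no higher from compound 2 to compound 3 (the limit leaves the size open). A reading at the limit of the assay is the likeliest outcome. The expected value for compound 3 is 36600 nM, with an estimated range from 18000 nM to 60000 nM.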

Compound 3, half-maximal effective concentration: > 36600 nM
Compound 3 ended at the assay's limit (the forecaster's own chance of this, stated with the estimate: 80%); the middle value lies on the limit itself.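

Compound 1, compound 2 and compound 3 all end at a limit and not at a number, so no step among them can be read: the limit of > 36600 nM in this assay, at which 3 of the 3 values shown sit.

The compounds shown leave open how much of each is needed for the effect in this assay, and whether swapping these groups changes that amount.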